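A few compounds are considered here, and "the series" means these few. Any claim that something is new, unique, unknown or untested is made for them only; others in the source may bear on it.

The three measured compounds share one core. In a functional assay on HT-29 cells (Homo sapiens) for cytotoxicity, read by sulforhodamine B assay, with a stated time of 48 h (a lower number here means a stronger inhibitor, a higher number a weaker inhibitor), compound 1 `O=C(NCCCCl)Nc1ccc(S(=O)(=O)Oc2ccc(O)cc2)cc1` gives 50000 nM. Compound 2 `Cc1ccccc1NS(=O)(=O)c1ccc(NC(=O)NCCCCl)cc1` gives 64000 nM in this assay, and the move a 1.3-fold higher number from compound 1 to compound 2 (0.11 log units; within the scatter). Compound 3 `CCc1ccccc1NS(=O)(=O)c1ccc(NC(=O)NCCCCl)cc1` stands at the limit of this assay, reported as > 200000 nM, which is a limit and not a number. Among the compounds with values here, the step of an at least 3.1-fold higher number from compound 2 to compound 3 (0.49 log units; beyond the scatter) is the one measured step that bears on what comes next. Compound 4 `CCCc1ccccc1NS(=O)(=O)c1ccc(NC(=O)NCCCCl)cc1` differs from compound 3 by methyl in place of hydrogen on a saturated chain carbon, two bonds along the chain from an aromatic carbon. Because the earlier lengthening of the same chain already ran into the limit (the limit of > 200000 nM in this assay, at which 1 of the 3 values shown sits), the further methyl is expected to give a number no lower, an expected step that the limit leaves unreadable from compound 3 to compound 4. Compound 4 is therefore estimated at 300000 nM, with a range from 150000 nM to 1000000 nM.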

Compound 4, half-maximal inhibitory concentration: 26000 nM
The estimate for compound 4 lay 12-fold (1.06 log units) above the measured number; the whole stated range lies above it.
By their numbers in this assay, from the lowest: compounds 4, 1 and 2 (each within the scatter of the next, the first and the last beyond it). At a limit, above all of these: compound 3.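

In this assay, turning 2-ethylphenyl into 2-propylphenyl gives an at least 7.6-fold lower number from compound 3 to compound 4 (0.88 log units; beyond the scatter), so lengthening this chain does not keep raising the number. Taking the ethyl group in place of hydrogen on the saturated chain carbon bound to an aromatic carbon gives a 2.5-fold lower number from compound 2 to compound 4 (0.39 log units; beyond the scatter), so the number does not follow chain length in one direction across these three compounds. The value for compound 3 is a limit and not a number: the limit of > 200000 nM in this assay, at which 1 of the 4 values shown sits.

On these data alone, whether a longer chain such as butyl would lower the number further remains open. So does the effect of an amine or a carboxylic acid on this chain, and the compounds shown do not explain the reversal.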